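This account rests on a few compounds, and the source may have more. Where it says the series, first, only, none or still open, it means among the compounds named here.

Measured compounds:
Compound 1 `CCN1CCN(c2ccc3oc([C@]4(CN5Cc6ccc(OC)c(F)c6C5=O)NC(=O)N(COC(=O)C(C)(C)C)C4=O)cc3n2)CC1`: 12700 ng.h/mL
Compound 2 `COc1ccc2c(c1F)C(=O)N(C[C@@]1(c3cc4nc(N5CCN(C)CC5)ccc4o3)NC(=O)N(COC(=O)C(C)(C)C)C1=O)C2`: 5350 ng.h/mL

Both were measured in an ADME assay on the whole organism for pharmacokinetics, with Rattus norvegicus as the target, read by LC-MS, at a dose of 10 mg/kg by the oral route; on this read-out lower numbers stand for lower exposure and higher numbers for higher exposure at the dose given. For the measured compounds named here, compound 2 stands lowest of the two numbers, with compound 1 as its only neighbour, and the one step between them, a 2.4-fold lower number from compound 1 to compound 2 (0.38 log units; beyond the scatter), lies beyond the scatter.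

Compound 3 `COc1ccc2c(c1F)C(=O)N(C[C@@]1(c3cc4nc(N5CCNC(=O)C5)ccc4o3)NC(=O)N(COC(=O)C(C)(C)C)C1=O)C2` has not yet been measured. It differs from compound 2 in one place: 3-oxopiperazin-1-yl in place of 4-methylpiperazin-1-yl on an aromatic carbon.

Going by the values given here, no measured step involves this kind of exchange; the only step at hand, a 2.4-fold lower number from compound 1 to compound 2 (0.38 log units; beyond the scatter), concerns a different part of the molecule and so gives little guidance here. With nothing to point in either direction, no step beyond the scatter is expected, and the estimate for compound 3 is a step of a 1.3-fold lower number from compound 2 to compound 3 (0.13 log units; within the scatter), set a little downward to allow for the uncertainty. Compound 3 is therefore estimated at 4000 ng.h/mL, with a range from 1300 ng.h/mL to 12000 ng.h/mL.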

Compound 3, area under the concentration-time curve: 374 ng.h/mL
For compound 3 the middle estimate is 11-fold (1.03 log units) above the measured one; the whole stated range lies above it.
By their numbers in this assay, from the lowest: compound 3; then compound 2; then compound 1.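

In this assay, putting 3-oxopiperazin-1-yl in place of 4-methylpiperazin-1-yl on the aromatic carbon next to the ring nitrogen gives a 14-fold lower number from compound 2 to compound 3 (1.16 log units; beyond the scatter) and the same group in place of 4-ethylpiperazin-1-yl gives a 34-fold lower number from compound 1 to compound 3 (1.53 log units; beyond the scatter) in the same read-out. Both steps are far larger than the earlier change on the chain alone, a 2.4-fold lower number from compound 1 to compound 2 (0.38 log units; beyond the scatter) and so the ring at this position matters much more to oral exposure in the rat than the length of that chain, even though the entering ring keeps the same size and the same count of heavy atoms while adding a carbonyl and the amide hydrogen. No measurement at hand bears on why the number falls.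

As far as these compounds go, it remains open whether the fall goes with the carbonyl or with the amide hydrogen. A 4-methyl-3-oxopiperazin-1-yl group or a morpholin-4-yl ring on this carbon would help to separate the two.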